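The source may report more compounds than this note shows. Statements on the series, on what has been measured and on what is new or still open speak of the compounds shown alone.

In an ADME assay on microsomes from liver (Homo sapiens), read by LC-MS, using NADPH, with a stated time of 30 min, tested at 1 uM (on this read-out lower numbers stand for a less stable compound and higher numbers for a more stable compound), compound 1 `C[C@H](Nc1ncnc2[nH]cnc12)c1cc2ccccn2c(=O)c1-c1ccccc1` gives 100%. Compound 2 `Cc1ccc2cc([C@H](C)Nc3ncnc4[nH]cnc34)c(-c3ccccc3)c(=O)n2c1` has no result in this assay, where it is recorded as "not determined" (no result reported). Compound 3 `C[C@H](Nc1nc(N)nc(N)c1C#N)c1cc2ccc(F)cn2c(=O)c1-c1ccccc1` gives 87% in this assay, the lower of the two numbers and below compound 1 by more than the usual scatter.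

Compound 4 `Cc1nc(N)nc(N[C@@H](C)c2cc3ccc(F)cn3c(=O)c2-c2ccccc2)c1C#N` differs from compound 3 by methyl in place of amino on an aromatic carbon. Going by the values given here, no pair of measured compounds shows this same change, so its effect is not known from these data. The step expected from compound 3 to compound 4 in this assay is a number 3 percentage points lower from compound 3 to compound 4 (within the scatter), a small shift that need not exceed the scatter. Compound 4 is estimated at 84%, with a range from 64% to 98%.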

Compound 4, percent of the compound remaining: 83%
Compound 4: middle estimate off by 1 percentage points, on the high side; low and high end bracket the measured number.
By their numbers in this assay, from the lowest: compounds 4 and 3 (each within the scatter of the next); then compound 1.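

In this assay, going by these compounds alone, the change from 2,6-diamino-5-cyanopyrimidin-4-yl to 2-amino-5-cyano-6-methylpyrimidin-4-yl gives a number 4 percentage points lower from compound 3 to compound 4 (within the scatter) and this is the first one-place comparison here. At this place, opposite the ring nitrogen, methyl and amino therefore cannot be told apart in this read-out, though this rests on a single pair.

Going by these compounds, whether a longer chain such as ethyl, or a methoxy group or a carboxylic acid, would read the same at this place stays open. No measurement shown offers a reason for the result.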